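Trading the chloro aryl for an aminophenyl on the shared core

The source may report more compounds than this note shows. Statements on the series, on what has been measured and on what is new or still open speak of the compounds shown alone.

For the measured compounds named here, compound 1 `Fc1cccc(-c2nc(Nc3ccc(Cl)cc3)c3cc(F)ccc3n2)c1` is the only member of this small set with a numeric result: in a functional assay on COLO 205 cells (Homo sapiens) for cytotoxicity, read by MTT assay, with a stated time of 48 h (a lower number here means a stronger inhibitor, a higher number a weaker inhibitor), compound 1 gives 32600 nM. Compound 2 `Oc1ccc(Nc2nc(-c3cccc(F)c3)nc3ccc(F)cc23)cc1` reaches only the limit of the assay, > 50000 nM. Compound 3 `Oc1cccc(Nc2nc(-c3cccc(F)c3)nc3ccc(F)cc23)c1` likewise stops at the limit, > 50000 nM. Both changes from compound 1 therefore read as losses of potency: an at least 1.5-fold higher number from compound 1 to compound 2 (0.18 log units; that floor lies within the scatter), and an at least 1.5-fold higher number from compound 1 to compound 3 (0.18 log units; that floor lies within the scatter). Between compound 2 and compound 3 the step cannot be read, a step that the two limits leave unreadable from compound 2 to compound 3.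

Compound 4 `Nc1ccccc1Nc1nc(-c2cccc(F)c2)nc2ccc(F)cc12` has not yet been tested in this assay. It differs from compound 1 as follows: 2-aminophenyl in place of 4-chlorophenyl on a nitrogen on an aromatic ring. The two measured steps away from compound 1 each removed the chloro, each brought in a hydroxy-bearing ring, and each ended at the limit (the limit of > 50000 nM in this assay, at which 2 of the 3 values shown sit). The change to compound 4 also removes the chloro and brings in a ring carrying a hydrogen-bond donor, so those two steps are the nearest guide, and a weaker result than compound 1, quite possibly again a limit, is expected. The expected step is a 1.8-fold higher number from compound 1 to compound 4 (0.26 log units; within the scatter). Compound 4 is estimated at about 60000 nM, within a range from 25000 nM to 150000 nM.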

Compound 4, half-maximal inhibitory concentration: > 50000 nM
Compound 4: no number, only a limit; the forecaster's own chance of this, stated with the estimate: 65%; the middle value does not contradict the limit.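

In this assay compound 4 gives > 50000 nM, which is a limit of the assay and not a number. The exchange of 4-chlorophenyl for 2-aminophenyl on the nitrogen therefore gives only a bound, an at least 1.5-fold higher number from compound 1 to compound 4 (0.18 log units; that floor lies within the scatter), while the steps among compounds 2, 3 and 4 cannot be read. What this adds is that an amino group, and not only a hydroxy group, fails to give a measurable value at this position, so 2-aminophenyl, 3-hydroxyphenyl and 4-hydroxyphenyl all end in the same place, and compound 1 remains the only compound with a number: the limit of > 50000 nM in this assay, at which 3 of the 4 values shown sit.

The compounds shown leave open whether the chloro itself matters for the value of compound 1 or whether the incoming hydroxy and amino groups matter, and a plain phenyl or a 4-fluorophenyl on the same nitrogen would help to separate the two. They also leave open how far compounds 2, 3 and 4 lie beyond the limit, and whether a 4-methoxyphenyl or a 3-chlorophenyl in this place would give a number at all.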